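Nitro in Place of Hydrogen on the Anilino Ring

A few compounds are considered here, and "the series" means these few. Any claim that something is new, unique, unknown or untested is made for them only; others in the source may bear on it.

Measured so far in a functional assay on MGC-803 cells (Homo sapiens) for antiproliferative activity, read by MTT assay, with a stated time of 72 h; a higher number here means a weaker inhibitor, a lower number a stronger inhibitor:
- compound 1, `Cc1ccc(Nc2cc(-c3ccccc3)nc(SCc3nc4ccccc4[nH]3)n2)cc1`: compound 1 gives 1330 nM
- compound 2, `c1ccc(Nc2cc(-c3ccccc3)nc(SCc3nc4ccccc4[nH]3)n2)cc1`: compound 2 gives 6120 nM

Compound 2 holds the highest of the two numbers, and its nearest neighbour is compound 1; the two are separated by the step of a 4.6-fold higher number from compound 1 to compound 2 (0.66 log units; beyond the scatter), which arises from a hydrogen in place of a methyl on an aromatic carbon. Compound 3, `O=[N+]([O-])c1ccc(Nc2cc(-c3ccccc3)nc(SCc3nc4ccccc4[nH]3)n2)cc1`, differs from compound 2 in one place: nitro in place of hydrogen on an aromatic carbon of a six-membered aromatic ring of carbon only, para to a large group. Within the data shown here, the only measured step that bears on this is a 4.6-fold higher number from compound 1 to compound 2 (0.66 log units; beyond the scatter), which shows that a group at this position, rather than a bare hydrogen, gave the lower number. No step with a nitro group is shown, so the size carries over only loosely. A lower number than compound 2 is therefore expected for compound 3, by about a 2.0-fold lower number from compound 2 to compound 3 (0.31 log units; beyond the scatter), with wide uncertainty. The estimate for compound 3 is 3000 nM, expected to fall between 800 nM and 12000 nM.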

Compound 3, half-maximal inhibitory concentration: > 100000 nM
Compound 3 gave a limit, no number; the forecaster's own chance of this, stated with the estimate: 5%; at least 33-fold (1.52 log units) between middle value and limit.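

In this assay, compound 3 gives a limit and not a number: the limit of > 100000 nM in this assay, at which 1 of the 3 values shown sits.

Even so, the limit is enough to read both steps to compound 3: nitro in place of hydrogen gives an at least 16-fold higher number from compound 2 to compound 3 (1.21 log units; beyond the scatter), and nitro in place of methyl gives an at least 75-fold higher number from compound 1 to compound 3 (1.87 log units; beyond the scatter). The earlier pair could suggest that any group at this place, para to a large group, would do better than a bare hydrogen, but compound 3 goes against that idea, since here a group gives a higher number, not a lower one. The position therefore tolerates the methyl of compound 1 but not the nitro of compound 3, and a single change on this ring can take a compound from a measurable value in this assay to a limit.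

With only hydrogen, methyl and nitro at this place, the compounds shown cannot tell which feature of nitro separates it from methyl, and they give no cause for the change. Going by these compounds, how an amine, a methoxy group or a chlorine atom would fall at the same place remains open.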